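A few compounds are considered here, and "the series" means these few. Any claim that something is new, unique, unknown or untested is made for them only; others in the source may bear on it.

Compound 1 `CCN(CC)CCCn1c(N)c(-c2nc3ccccc3n2C)c2nc(C#N)c(C#N)nc21` was tested in an ADME assay on HEK293 cells (Homo sapiens) for cytotoxicity, read by MTT assay, with a stated time of 48 h (on this read-out lower numbers stand for stronger inhibition and higher numbers for weaker inhibition), where compound 1 gives 7240 nM. Compound 2 `CN(C)CCCCn1c(N)c(-c2nc3ccccc3n2C)c2nc(C#N)c(C#N)nc21` carries (dimethylamino)methyl in place of diethylamino on a saturated chain carbon, three bonds along the chain from an aromatic nitrogen; in this assay compound 2 gives 3870 nM, and the step of a 1.9-fold lower number from compound 1 to compound 2 (0.27 log units; within the scatter) is small. Compound 3 `CCN(CC)CCn1c(N)c(-c2nc3cc(Cl)ccc3[nH]2)c2nc(C#N)c(C#N)nc21` has a different core, and how its core differs from that of compound 1 is not broken down here. In this assay compound 3 reaches only a limit, > 50000 nM, which is the limit of > 50000 nM in this assay, at which 1 of the 3 values shown sits. Compound 4 `CN(C)CCCn1c(N)c(-c2nc3cc(Cl)ccc3[nH]2)c2nc(C#N)c(C#N)nc21` is not yet measured and differs from compound 3 by (dimethylamino)methyl in place of diethylamino on a saturated chain carbon, two bonds along the chain from an aromatic nitrogen, the same kind of change as that between compound 1 and compound 2, though here the place is two bonds along the chain from an aromatic nitrogen rather than three. The matching step a 1.9-fold lower number from compound 1 to compound 2 (0.27 log units; within the scatter) stayed within the scatter. The step of a number no higher from compound 3 to compound 4 (the limit leaves the size open) is therefore expected to be similarly small. Compound 4 is accordingly estimated at 50000 nM, between 20000 nM and 120000 nM, most probably reported again only as a limit.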

Compound 4, half-maximal inhibitory concentration: 11700 nM
Compound 4: the middle estimate sits 4.3-fold (0.63 log units) above what was measured, outside the stated range (below it).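

In this assay, putting 3-(dimethylamino)propyl in place of 2-(diethylamino)ethyl gives an at least 4.2-fold lower number from compound 3 to compound 4 (0.63 log units; beyond the scatter). This does not show that the change has a larger effect on one core than on the other, and the two cores compare as follows: the same change on two cores in this assay, a 1.9-fold lower number (0.27 log units; within the scatter) from compound 1 to compound 2 and an at least 4.2-fold lower number (0.63 log units; beyond the scatter) from compound 3 to compound 4; the limit leaves it open whether they differ. For compound 3, the reading > 50000 nM is a limit of the assay and not a number.

The compounds shown leave open how the comparison would read with a pyrrolidine or a morpholine in place of the open-chain amines, or with a longer chain on the core of compound 3. They also do not separate the chlorine from the other differences between the two cores.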